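A few compounds are considered here, and "the series" means these few. Any claim that something is new, unique, unknown or untested is made for them only; others in the source may bear on it.

Measured so far:
compound 1 `COC(=O)c1ccc(OCCCCOc2ccc(C(=O)CC(C)C)c(O)c2C)cc1` — 22.7%
compound 2 `Cc1c(OCCCCOc2ccc(C(=O)O)c(Cl)c2)ccc(C(=O)CC2CCCC2)c1O` — 40%

In an assay on HEK293 cells for positive allosteric modulation of metabotropic glutamate receptor 3 (Rattus norvegicus), read by thallium flux, with a stated time of 2.5 min (on this read-out lower numbers stand for smaller maximal responses and higher numbers for larger maximal responses), compound 2 stands highest of the two numbers; its nearest neighbour, compound 1, gives 22.7%, a gap beyond the usual scatter. Compound 3 `Cc1c(OCCCCOc2ccc(C(=O)O)c(Cl)c2)ccc(C(=O)CC(C)C)c1O` has not been measured. It differs from compound 2 in one place: isopropyl in place of cyclopentyl on a saturated chain carbon bound to a carbonyl carbon. For the measured compounds named here, no measured pair shows this change, so its effect is unknown. A modest downward step is expected, a number 8 percentage points lower from compound 2 to compound 3 (within the scatter), but one that may fall within the scatter. Compound 3 is therefore estimated at 32%, between 18% and 48%.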

Compound 3, largest response reached (reported as percent of maximum), in percent of the reference or control that the assay uses: 49.5%
The estimate for compound 3 lay 17.5 percentage points below the measured number; the measured number lies above the stated range.
By their numbers in this assay, from the lowest: compound 1; then compounds 2 and 3 (each within the scatter of the next).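

In this assay the exchange of cyclopentyl for isopropyl on a saturated chain carbon bound to a carbonyl carbon gives a number 9.5 percentage points higher from compound 2 to compound 3 (within the scatter) and so shows no real change: the ring is not needed here for the response. Exchanging 4-(methoxycarbonyl)phenyl for 4-carboxy-3-chlorophenyl gives a number 26.8 percentage points higher from compound 1 to compound 3 (beyond the scatter) and does change the response. Nothing measured here explains either step.

On these data alone, that second exchange alters the ester and the chlorine together, so their separate shares remain unknown. Also open, as far as these compounds go, is how a cyclohexyl or tert-butyl group on the chain carbon, or an amide in place of the acid, would behave.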